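Swapping butoxy for bromo on a sulfone

The compounds below may be only part of what the source reports. "The series", "measured", "known", "first", "only" and "open" are said of these compounds alone.

Measured in a functional assay on MT4 cells (Homo sapiens) for cytotoxicity; a higher number here means a weaker inhibitor, a lower number a stronger inhibitor:
compound 1 `N#Cc1c(N)cccc1Sc1cccc(Cl)c1`: 53000 nM
compound 2 `CCCCOc1cc(C)cc(S(=O)(=O)c2cccc(N)c2C#N)c1`: > 2000 nM
compound 3 `Cc1ccc(S(=O)(=O)c2cccc(N)c2C#N)cc1`: > 200000 nM

For the measured compounds named here, only one of these three entries is a true number, and that is the one for compound 1. Compound 2 has no exact reading in this assay: it gives > 2000 nM, which is a limit of the assay and not a number. Compound 3 gives > 200000 nM, and this is also a limit. On these data alone, the position of compound 2 is therefore only partly fixed, and its true value is unknown.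

Compound 4 `Cc1cc(Br)cc(S(=O)(=O)c2cccc(N)c2C#N)c1` has bromo in place of the butoxy of compound 2, on an aromatic carbon, meta to a large group and meta to a methyl group (bromo in place of butoxy on an aromatic carbon). Going by the values given here, no measured pair in this small set shows this kind of change directly, so any forecast is rough. Among the compounds with values here, the expectation rests mainly on compound 1 at 53000 nM, the only true number available. The expected step is a step that the limit leaves unreadable from compound 2 to compound 4, towards a higher number and so a weaker reading, although the limit for compound 2 leaves its real size open. For compound 4 the estimated value is 40000 nM, with an expected range from 6000 nM to 200000 nM.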

Compound 4, half-maximal inhibitory concentration: 133000 nM
Beside the measured number, compound 4's estimate is 3.3-fold (0.52 log units) below it, and the stated range covers the measured number.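

No step from compound 2 to compound 4 can be read, since compound 2 carries only a limit and not a number, so the swap of butoxy for bromo has no measurable size: the limit of > 2000 nM in this assay, at which 1 of the 4 values shown sits.

The compounds shown leave open how far apart compound 2 and compound 4 truly lie in this assay, and even in which direction.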